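Acid-Series Swap of Chloroacetamide for Acrylamide

This account rests on a few compounds, and the source may have more. Where it says the series, first, only, none or still open, it means among the compounds named here.

The measured compounds:
- compound 1, `C=CC(=O)Nc1cccc(Cn2nc(-c3ccc(Oc4ccccc4)cc3)cc2C(=O)OCC)c1`, 8600 nM in a functional assay on Maver1 cells (Homo sapiens) for inhibition, read by luminescence and CellTiter-Glo, with a stated time of 72 h; a lower number here means a stronger inhibitor, a higher number a weaker inhibitor
- compound 2, `O=C(CCl)Nc1ccc(Cn2nc(-c3ccc(Oc4ccccc4)cc3)cc2C(=O)O)cc1`, 1200 nM
- compound 3, `CCOC(=O)c1cc(-c2ccc(Oc3ccccc3)cc2)nn1Cc1ccc(NC(=O)CCl)cc1`, 400 nM

Among the three numbers, compound 2 stands second highest; its nearest neighbour is compound 3, reached by a 3.0-fold lower number from compound 2 to compound 3 (0.48 log units; beyond the scatter), while the furthest is compound 1, which sits higher than compound 2.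

Compound 4, `C=CC(=O)Nc1cccc(Cn2nc(-c3ccc(Oc4ccccc4)cc3)cc2C(=O)O)c1`, has not yet been tested in this assay. It differs from compound 2 in one place: 3-((vinylcarbonyl)amino)phenyl in place of 4-(((chloromethyl)carbonyl)amino)phenyl on a saturated chain carbon bound to an aromatic nitrogen.

For the measured compounds named here, one measured step bears directly on this exchange, though it runs the other way and on the ethyl ester rather than the acid: a 22-fold lower number from compound 1 to compound 3 (1.33 log units; beyond the scatter). The step of a 3.0-fold lower number from compound 2 to compound 3 (0.48 log units; beyond the scatter) links the acid and ester series and shows a modest gap between them. Taken together, compound 4 would be expected to resemble compound 1 shifted by roughly the acid-versus-ester gap, and compound 2 shifted by roughly the reverse of the large step seen between compound 1 and compound 3.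

Compound 4 is therefore expected to give a clearly higher number, a 21-fold higher number from compound 2 to compound 4 (1.32 log units; beyond the scatter), with an estimated value of 25000 nM and a range from 8000 nM to 80000 nM.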

Compound 4, half-maximal inhibitory concentration: 37400 nM
Compound 4: the middle estimate sits 1.5-fold (0.17 log units) below what was measured; the range from low to high includes it.
By their numbers in this assay, from the lowest: compound 3; then compound 2; then compound 1; then compound 4.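

In this assay, the exchange of 4-(((chloromethyl)carbonyl)amino)phenyl for 3-((vinylcarbonyl)amino)phenyl on a saturated chain carbon bound to an aromatic nitrogen proves as large on the acid as on the ethyl ester, with a 31-fold higher number from compound 2 to compound 4 (1.49 log units; beyond the scatter), so the large effect of this change is not confined to the ester series: the same change on two cores in this assay, a 22-fold lower number (1.33 log units; beyond the scatter) from compound 1 to compound 3 and a 31-fold lower number (1.49 log units; beyond the scatter) from compound 4 to compound 2, 1.4-fold (0.16 log units) apart, within the scatter of two such steps The acid and ester forms now also form a second pair carrying the 3-((vinylcarbonyl)amino)phenyl group, with a 4.3-fold higher number from compound 1 to compound 4 (0.64 log units; beyond the scatter), so the modest advantage of ethyl over hydrogen on the oxygen next to a carbonyl group recurs: the same change on two cores in this assay, a 3.0-fold lower number (0.48 log units; beyond the scatter) from compound 2 to compound 3 and a 4.3-fold lower number (0.64 log units; beyond the scatter) from compound 4 to compound 1, 1.4-fold (0.16 log units) apart, within the scatter of two such steps Across these four compounds, each change therefore keeps its size whichever group occupies the other place, and none of the four goes against this.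

Every compound shown pairs the chloromethyl end with the 4-substituted phenyl and the vinyl end with the 3-substituted phenyl, so the large step cannot be divided between the two, and a 4-((vinylcarbonyl)amino)phenyl group would be needed to separate them. The compounds also leave open whether the same pattern would hold with a primary amide in place of the acid or ethyl ester.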